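The source may report more compounds than this note shows. Statements on the series, on what has been measured and on what is new or still open speak of the compounds shown alone.

Three compounds of the shared core have been run in an assay on isolated protein for inhibition of DNA topoisomerase 1 (Homo sapiens), with a stated time of 15 min, tested at 200 uM; on this read-out lower numbers stand for less inhibition and higher numbers for more inhibition at the one concentration tested (going by the name of the read-out). Compound 1 `NC[C@@H]1CCN(c2cc3c(cc2F)c(=O)c(C(=O)O)cn3Cc2nc(-c3ccncc3)no2)C1` gives 10% in this assay. Compound 2 `COc1c(N2CC[C@@H](CN)C2)c(F)cc2c(=O)c(C(=O)O)cn(Cc3ccc(-n4cccn4)cc3)c12` gives 10%, and compound 3 `CNCCNc1c(F)cc2c(=O)c(C(=O)O)cn(Cc3ccc(-c4ccccc4)cc3)c2c1OC` gives 10%. Compound 1 stands level with compound 2 and compound 3 at the digits shown; the gap to either lies within the scatter, so no order among the three can be read from these numbers. For the measured compounds named here, no pair of measured compounds differs in only one place, so the size of a single structural step is unknown.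

Compound 4 `CC(c1nc(-c2ccncc2)no1)n1cc(C(=O)O)c(=O)c2cc(F)c(N3CC[C@@H](CN)C3)cc21` is not yet measured in this assay. It differs from compound 1 by methyl in place of hydrogen on a saturated chain carbon bound to an aromatic carbon and an aromatic nitrogen. Going by the values given here, with every measured compound at the same level and no measured step to lean on, no change beyond the scatter is expected from this substitution. Compound 4 is estimated at 10%, with a range from 0% to 25%. The expected step of no change at the digits printed from compound 1 to compound 4 (within the scatter) is essentially none beyond the scatter.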

Compound 4, a percentage reported as inhibition, at one concentration (the size of the read-out at that concentration, not a potency): 10%
For compound 4 middle estimate and measured number coincide at the digits printed, and the stated range covers the measured number.
By their numbers in this assay, from the lowest: compounds 1, 2, 3 and 4 (each within the scatter of the next).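

In this assay, for the compounds shown here, methyl in place of hydrogen on a saturated chain carbon bound to an aromatic carbon and an aromatic nitrogen gives no change at the digits printed from compound 1 to compound 4 (within the scatter), the first step that can be read at a single place. This position therefore accepts one added carbon with no shift beyond the scatter at the one concentration tested, although a read-out this low leaves little room to detect any further loss. No measured information bearing on the reason for this result is available.

On these data alone, whether an ethyl group or a hydroxymethyl group on the same carbon would alter the read-out remains open. As far as these compounds go, it is also open whether the same methyl change would leave compound 2 or compound 3 equally unmoved.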